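Fluoro on the fused carbocycle: compound 4 against compound 1

The compounds below may be only part of what the source reports. "The series", "measured", "known", "first", "only" and "open" are said of these compounds alone.

The series shares one core; compound 1 is `CC1CCN(c2c(S(=O)(=O)c3ccccc3)cnc3ccccc23)CC1`. Among the compounds with values here, in an assay on isolated protein for displacement of a labelled ligand from metabotropic glutamate receptor 5 (Homo sapiens), with a stated time of 60 min, tested at 1 uM (a lower number here means less inhibition, a higher number more inhibition at the concentration tested (going by the name of the read-out)), compound 1 gives 89.2%, the second highest of the three numbers measured so far, with compound 2 near it within the scatter and compound 3 far below it beyond the scatter. Compound 2 is `CC1CCN(c2c(S(=O)(=O)c3ccccc3)cnc3cc(Cl)ccc23)CC1` and gives 93% in this assay; the step is a number 3.8 percentage points higher from compound 1 to compound 2 (within the scatter). Compound 3 is `O=S(=O)(c1ccccc1)c1cnc2ccccc2c1N1CCCC1` and gives 7.1% in this assay; the step is a number 82.1 percentage points lower from compound 1 to compound 3 (beyond the scatter).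

Compound 4, `CC1CCN(c2c(S(=O)(=O)c3ccccc3)cnc3ccc(F)cc23)CC1`, has not yet been measured. It differs from compound 1 by fluoro in place of hydrogen on an aromatic carbon. The measured step that bears on it is a number 3.8 percentage points higher from compound 1 to compound 2 (within the scatter), likewise a halogen entering the core where a hydrogen stood, and a step that stayed within the scatter. The step of a number 82.1 percentage points lower from compound 1 to compound 3 (beyond the scatter) concerns the amine side of the core and does not speak to this change. A step of a number 1.2 percentage points lower from compound 1 to compound 4 (within the scatter) is therefore expected, none beyond the scatter, in either direction. Compound 4 is estimated to give 88% in this assay, within a range of 78% to 95%.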

Compound 4, a percentage reported as inhibition, at one concentration (the size of the read-out at that concentration, not a potency): 40%
Estimate against measurement, compound 4: 48 percentage points above, and the stated range ends above it.
By their numbers in this assay, from the lowest: compound 3; then compound 4; then compounds 1 and 2 (each within the scatter of the next).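

The fluoro result shows that the carbon-only ring of the shared core is not a position where substitution passes unnoticed in this assay: a single fluoro, one heavy atom with no ring and no net charge, gives a number 49.2 percentage points lower from compound 1 to compound 4 (beyond the scatter) on a carbon meta to a fused ring and para to a fused ring. Set against a number 3.8 percentage points higher from compound 1 to compound 2 (within the scatter) with chloro, this means that a halogen entering this ring does not in itself leave the read-out unchanged, and the outcome depends on which halogen, on which carbon, or on both, since compound 2 and compound 4 differ in both of these at once. Nothing shown here gives a reason for the size of the fluoro step.

From the compounds shown here alone, what remains open is whether the step follows the carbon or the halogen, which chloro on the carbon that bears fluoro in compound 4, or fluoro on the carbon that bears chloro in compound 2, would separate. Also open, going by these compounds, is how a larger group such as methoxy or a nitrile would fare on the fluoro-bearing carbon.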